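Replacing a bromine by a phenyl ring on a chalcone

The source may report more compounds than this note shows. Statements on the series, on what has been measured and on what is new or still open speak of the compounds shown alone.

Compound 3 `COc1ccc(C(=O)/C=C/c2ccc(Br)cc2)c2c1C=CC(C)(C)O2` was tested in a functional assay on SK-OV-3 cells (Homo sapiens) for antiproliferative activity, read by MTT assay, with a stated time of 24 h; a higher number here means a weaker inhibitor, a lower number a stronger inhibitor. In this assay compound 3 gives only a limit, > 10000 nM, not a number. Its closest relatives are compound 1 `COc1cccc(/C=C/C(=O)c2ccc(OC)c3c2OC(C)(C)C=C3)c1`, which in this assay gives 9360 nM, and compound 2 `COc1ccc(C(=O)/C=C/c2ccc(F)cc2)c2c1C=CC(C)(C)O2`. For compound 2 this assay also reports only a limit, > 10000 nM. The step from the methoxyphenyl of compound 1 to the halogenated rings is an at least 1.0-fold higher number from compound 1 to compound 2 (0.02 log units; that floor lies within the scatter) and an at least 1.0-fold higher number from compound 1 to compound 3 (0.02 log units; that floor lies within the scatter), while the exchange of halogens is a step that the two limits leave unreadable from compound 2 to compound 3. Two of the three values sit at the same ceiling, (the limit of > 10000 nM in this assay, at which 2 of the 3 values shown sit), so compound 3 stands no better than any other compound here.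

Compound 4 `COc1ccc(C(=O)/C=C/c2ccc(-c3ccccc3)cc2)c2c1C=CC(C)(C)O2` differs from compound 3 by phenyl in place of bromo on an aromatic carbon. Within the data shown here, no measured step swaps a halogen for a ring on this position, so the only guide is that every change on this ring so far left the compounds weak, and compound 1 is the one that gave a number at all. The expected step from compound 3 to compound 4 is therefore a step that the limit leaves unreadable from compound 3 to compound 4, with no clear direction beyond the scatter. Compound 4 is expected to give about 13000 nM in this assay, within a range from 5000 nM to 35000 nM.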

Compound 4, half-maximal inhibitory concentration: > 10000 nM
Compound 4: only a limit was reported; the forecaster's own chance of this, stated with the estimate: 60%; the middle value is on the limit's open side.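

Among these compounds, compound 4, like compound 2 and compound 3, gives only a limit in this assay, so no step from either of them to compound 4 can be read: the limit of > 10000 nM in this assay, at which 3 of the 4 values shown sit. The compounds shown leave open how strongly compound 2, compound 3 and compound 4 really inhibit, and whether fluoro, bromo or phenyl on this ring makes any difference.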